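The source may hold more compounds than are shown below. What is called first, only, known or untested is meant among the compounds shown, and "the series" means these compounds.

Measured so far:
compound 1, `CC1(C)[C@H]2CC[C@]1(C)N(Cc1cn(-c3ccccc3C#N)nn1)C(=O)C2`: in a functional assay on A549 cells (Homo sapiens) for inhibition, read by MTT assay, with a stated time of 24 h (a lower number here means a stronger inhibitor, a higher number a weaker inhibitor), compound 1 gives 100 nM
compound 2, `CC1(C)[C@H]2CC[C@]1(C)N(Cc1cn(-c3ccccc3F)nn1)C(=O)C2`: in this assay compound 2 gives 240 nM

For the measured compounds named here, compound 2 holds the higher of the two numbers; its nearest neighbour is compound 1, and the only recorded step, a 2.4-fold higher number from compound 1 to compound 2 (0.38 log units; beyond the scatter), is modest. Compound 3, `CC1(C)[C@H]2CC[C@]1(C)N(Cc1cn(-c3ccccc3)nn1)C(=O)C2`, differs from compound 2 by hydrogen in place of fluoro on an aromatic carbon. Going by the values given here, no measured step removes a substituent outright; the one step available exchanges cyano for fluoro. On that basis the change is expected to stay near the scatter, with a small upward step if any, a 1.3-fold higher number from compound 2 to compound 3 (0.12 log units; within the scatter). The estimate for compound 3 in this assay is 320 nM, with a range of 150 nM to 700 nM.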

Compound 3, half-maximal inhibitory concentration: 70 nM
Beside the measured number, compound 3's estimate is 4.6-fold (0.66 log units) above it; measured number below the stated range.
By their numbers in this assay, from the lowest: compounds 3 and 1 (each within the scatter of the next); then compound 2.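

In this assay, hydrogen in place of fluoro gives a 3.4-fold lower number from compound 2 to compound 3 (0.54 log units; beyond the scatter) and shows that the 2-fluorophenyl to phenyl change is not neutral at this position. Hydrogen in place of cyano gives a 1.4-fold lower number from compound 1 to compound 3 (0.15 log units; within the scatter) and leaves compound 2 as the one compound of the three that stands apart, so a substituent on this aromatic carbon is not needed for a low number. No evidence at hand explains why fluoro differs from hydrogen or cyano here.

Still open, from the compounds shown here alone, is how a methoxy group, an amine or a carboxylic acid on this carbon would read. Also open, going by these compounds, is whether chloro would follow fluoro or hydrogen.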